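Benzoyl to 1-hydroxybutyl on the compound 1 side chain

The compounds below may be only part of what the source reports. "The series", "measured", "known", "first", "only" and "open" are said of these compounds alone.

In a functional assay on HL60/MX2 cells (Homo sapiens) for inhibition, with a stated time of 48 h (a higher number here means a weaker inhibitor, a lower number a stronger inhibitor), compound 1 (`C#CCOC(=O)C1=C(N)Oc2ccc(-c3cc(OC)cc(OC)c3)cc2C1CC(=O)c1ccccc1`) gives 5900 nM and stands level, within the scatter, with compound 2 (`CCCC(=O)CC1C(C(=O)OCC)=C(N)Oc2ccc(-c3cc(OC)cc(OC)c3)cc21`) at 11700 nM and clearly higher than compound 3 (`C#CCOC(=O)CC1C(C(=O)OCC#C)=C(N)Oc2ccc(-c3cc(OC)cc(OC)c3)cc21`) at 860 nM in the set of three. Compound 4 (`C#CCOC(=O)C1=C(N)Oc2ccc(-c3cc(OC)cc(OC)c3)cc2C1CC(O)CCC`) differs from compound 1 as follows: 1-hydroxybutyl in place of benzoyl on a saturated chain carbon bound to a saturated ring carbon with 1-hydroxybutyl in place of benzoyl on a saturated chain carbon bound to a saturated ring carbon. Going by the values given here, the one measured step touching this side chain is a 6.9-fold lower number from compound 1 to compound 3 (0.84 log units; beyond the scatter) and it also removes the phenyl. Compound 2 lacks that phenyl too, yet gives 11700 nM in this assay so only a small lowering is expected, possibly none beyond the scatter. The estimated step is a 1.5-fold lower number from compound 1 to compound 4 (0.17 log units; within the scatter) at this stage. Compound 4 is estimated at 4000 nM with 1500 nM to 11000 nM as the expected range.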

Compound 4, half-maximal inhibitory concentration: 35800 nM
Compound 4: the middle estimate sits 9.0-fold (0.95 log units) below what was measured; the measured number lies above the stated range.
By their numbers in this assay, from the lowest: compound 3; then compounds 1 and 2 (each within the scatter of the next); then compound 4.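

In this assay, the place on a saturated chain carbon bound to a saturated ring carbon tolerates some groups far better than others: 1-hydroxybutyl in place of benzoyl gives (a 6.1-fold higher number from compound 1 to compound 4 (0.78 log units; beyond the scatter)). Losing the phenyl therefore does not settle the outcome, since propargyloxycarbonyl at this place compares very differently with 1-hydroxybutyl (a 42-fold higher number from compound 3 to compound 4 (1.62 log units; beyond the scatter)). No available evidence explains these steps.

Open, from the compounds shown here alone, is whether the hydroxyl or the phenyl-free chain accounts for the rise. A butanoyl group on compound 1's side chain would separate the two, and a carboxylic acid would test another end group.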